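Isopropyl to tert-butyl ester on the proline urea of compound 3

The source may report more compounds than this note shows. Statements on the series, on what has been measured and on what is new or still open speak of the compounds shown alone.

Three ureas sharing one amide-linked core have been measured. Compound 1 `CCOC(=O)CNC(=O)NCc1ccc(C(=O)N2CCCCc3ccccc32)cc1C` gives 140 nM in a functional assay on HEK293 cells for agonist activity at Vasopressin V2 receptor (Homo sapiens), read by a luciferase reporter and cAMP accumulation; a higher number here means that more compound is needed for the effect, a lower number that less compound is needed. Compound 2 `Cc1cc(C(=O)N2CCCCc3ccccc32)ccc1CNC(=O)NCC(=O)N1CCCC1` gives 100 nM in this assay, and the step of a 1.4-fold lower number from compound 1 to compound 2 (0.15 log units; within the scatter) is within the scatter. Compound 3 `Cc1cc(C(=O)N2CCCCc3ccccc32)ccc1CNC(=O)N1CCC[C@H]1C(=O)OC(C)C` gives 950 nM in this assay; it carries the highest number of the three, with a 6.8-fold higher number from compound 1 to compound 3 (0.83 log units; beyond the scatter) and a 9.5-fold higher number from compound 2 to compound 3 (0.98 log units; beyond the scatter) both beyond the scatter.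

Compound 4 `Cc1cc(C(=O)N2CCCCc3ccccc32)ccc1CNC(=O)N1CCC[C@H]1C(=O)OC(C)(C)C` is unmeasured. It differs from compound 3 by methyl in place of hydrogen on a saturated chain carbon bound to an oxygen next to a carbonyl group and two saturated chain carbons. Among the compounds with values here, no measured step matches this change: the steps into compound 3 replace a whole urea substituent, not one alkyl hydrogen of the ester. They show that the ester region of compound 3 tolerates large rearrangement with only modest movement in this assay, so a single added methyl is expected to move the number little, with no step beyond the scatter, a 1.1-fold higher number from compound 3 to compound 4 (0.02 log units; within the scatter). Compound 4 is therefore estimated at 1000 nM in this assay, with a range of 400 nM to 2500 nM.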

Compound 4, half-maximal effective concentration: 390 nM
The estimate for compound 4 lay 2.6-fold (0.41 log units) above the measured number, outside the stated range (below it).
By their numbers in this assay, from the lowest: compounds 2 and 1 (each within the scatter of the next); then compound 4; then compound 3.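

The ester alkyl group on the proline urea responds to a small change: in this assay, isopropyl to tert-butyl gives a 2.4-fold lower number from compound 3 to compound 4 (0.39 log units; beyond the scatter) and so moves the number beyond the scatter with one added methyl. That gain does not close the gap to the open-chain ureas, as a 3.9-fold higher number from compound 2 to compound 4 (0.59 log units; beyond the scatter) and a 2.8-fold higher number from compound 1 to compound 4 (0.44 log units; beyond the scatter) both remain beyond the scatter. Nothing available explains why the added methyl lowers the number.

Still open, going by these compounds, is whether the number falls further with other esters on the proline urea, such as a cyclopentyl ester or a longer branched chain. Also open, on these data alone, is whether any ester is needed, which a carboxylic acid or a primary amide in place of tert-butoxycarbonyl would test.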